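The source may report more compounds than this note shows. Statements on the series, on what has been measured and on what is new or still open speak of the compounds shown alone.

Compound 1 `COc1ccc(Cl)cc1C(C)NC(=O)N(C)S(=O)(=O)c1ccccc1` gives 7200 nM as measured
Compound 2 `CCOc1ccc(Br)cc1C(C)NC(=O)N(C)S(=O)(=O)c1ccccc1` gives 19800 nM as measured
Compound 3 `COc1ccc(Br)cc1C(C)NC(=O)N(C)S(=O)(=O)c1ccccc1` has not been measured yet

In a functional assay on thoracic aorta (Rattus norvegicus, strain Wistar), with a stated time of 15 min (on this read-out lower numbers stand for an effect already at smaller amounts and higher numbers for an effect only at larger amounts of compound), compound 2 stands at 19800 nM as the higher of the two numbers. Compound 1 at 7200 nM lies lower, and this gap is beyond the usual scatter. Compound 2 therefore needs the larger amount to show its effect. The move to compound 3 changes one place (hydrogen in place of methyl on a saturated chain carbon bound to an oxygen on an aromatic ring): hydrogen in place of methyl on a saturated chain carbon bound to an oxygen on an aromatic ring, which turns ethoxy into methoxy. For the measured compounds named here, no measured pair shows this change on its own, so its size can only be judged loosely. Going by the values given here, the one lower number so far, compound 1 with 7200 nM as its value, gives a weak hint. A modest move toward a smaller number in this assay is expected, near the edge of the scatter, and not a large one. The expected size is a 2.0-fold lower number from compound 2 to compound 3 (0.30 log units; within the scatter) in this estimate. For compound 3 the estimated value is 10000 nM with an expected range from 4500 nM to 22000 nM as the likely span.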

Compound 3, half-maximal effective concentration: 16800 nM
Beside the measured number, compound 3's estimate is 1.7-fold (0.23 log units) below it; low and high end bracket the measured number.
By their numbers in this assay, from the lowest: compound 1; then compounds 3 and 2 (each within the scatter of the next).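

In this assay, for the compounds shown here, turning ethoxy into methoxy, with hydrogen in place of methyl on a saturated chain carbon bound to an oxygen on an aromatic ring, gives a 1.2-fold lower number from compound 2 to compound 3 (0.07 log units; within the scatter), so in this pair, the one change in the chain on that oxygen cannot be told apart from repeat-measurement noise. Going by these compounds alone, compound 3 also isolates a second change for the first time, bromo in place of chloro on an aromatic carbon, which gives a 2.3-fold higher number from compound 1 to compound 3 (0.37 log units; beyond the scatter) and is the only one of the two single changes that is printed as beyond the scatter. Nothing measured alongside these numbers accounts for either step.

The compounds shown carry only methoxy or ethoxy on that oxygen, so they leave open how a longer chain such as butoxy, or a bare hydroxyl, would read on the same core. As far as these compounds go, they carry only chloro or bromo on the aromatic carbon as well, so it remains open where fluoro or a nitrile would fall, and whether the chloro-to-bromo step would look the same with ethoxy in place of methoxy.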